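This account rests on a few compounds, and the source may have more. Where it says the series, first, only, none or still open, it means among the compounds named here.

Compound 1, `CN(C)CCCNc1nc(-c2ccc(NC(=O)Nc3ccccc3F)cc2)nc2ccsc12`: 730 nM
Compound 2, `CN(C)CCCNc1nc(-c2ccc(NC(=O)Nc3ccccc3Cl)cc2)nc2ccsc12`: 690 nM

In a functional assay on MKN-45 cells (Homo sapiens) for cytotoxicity, read by MTT assay, with a stated time of 72 h (on this read-out lower numbers stand for stronger inhibition and higher numbers for weaker inhibition), compound 1 gives 730 nM and compound 2 gives 690 nM; the step of a 1.1-fold lower number from compound 1 to compound 2 (0.02 log units; within the scatter) is within the scatter, so the two read alike. Compound 3, `CN(C)CCNc1nc(-c2ccc(NC(=O)Nc3ccccc3F)cc2)nc2ccsc12`, differs from compound 1 by dimethylamino in place of (dimethylamino)methyl on a saturated chain carbon, two bonds along the chain from a nitrogen on an aromatic ring. Within the data shown here, the one measured step swaps a halogen on a different part of the molecule and says nothing about shortening this chain. With no guide, compound 3 is expected to stay close to compound 1, a step of a 1.0-fold higher number from compound 1 to compound 3 (0.01 log units; within the scatter) within the scatter. The estimate for compound 3 is 750 nM, ranging from 250 nM to 2200 nM.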

Compound 3, half-maximal inhibitory concentration: 530 nM
Estimate against measurement, compound 3: 1.4-fold (0.15 log units) above; low and high end bracket the measured number.
By their numbers in this assay, from the lowest: compounds 3, 2 and 1 (each within the scatter of the next).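

In this assay the change from 3-(dimethylamino)propyl to 2-(dimethylamino)ethyl gives a 1.4-fold lower number from compound 1 to compound 3 (0.14 log units; within the scatter) and so the two compounds read alike. Among these compounds, the earlier pair differed only in the halogen, so this is the first reading on the chain, and it shows that this trimmed chain keeps the number within the scatter. Nothing measured here bears on why the two read alike. Still open, on these data alone, is whether a longer chain, or a morpholine in place of dimethylamino, would also read alike, and whether the same chain change behaves the same way with chloro on the aromatic ring, as in compound 2.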